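The compounds below may be only part of what the source reports. "The series", "measured", "known", "first", "only" and "open" are said of these compounds alone.

Measured so far in a physicochemical assay for metabolic stability, read by HPLC, at pH 4.5, tested at 10 uM; on this read-out higher numbers stand for a longer-lived compound and lower numbers for a shorter-lived compound:
- compound 1 `Cc1ccccc1CNC(=O)n1c(N)nc2ccccc21`: 0.45 h
- compound 2 `Cc1cccc(CNC(=O)n2c(N)nc3ccccc32)c1`: 0.45 h

Going by the values given here, the one step so far, no change at the digits printed from compound 1 to compound 2 (within the scatter), comes with 3-methylphenyl in place of 2-methylphenyl on a saturated chain carbon bound to an amide-type nitrogen. On the numbers shown, compound 2 stands level with compound 1 at the digits printed; the two values lie within the scatter of each other, so no ordering between them is claimed.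

The next compound, compound 3 `Nc1nc2ccccc2n1C(=O)NCc1ccccc1`, has yet to be measured in this assay. It differs from compound 2 by hydrogen in place of methyl on an aromatic carbon. Among the compounds with values here, no measured step removes a methyl outright; the only step known, no change at the digits printed from compound 1 to compound 2 (within the scatter), moves the methyl around the ring without altering the read-out beyond the scatter. That step bears on the question only loosely, but it gives no sign that the read-out responds to this part of the molecule.

Compound 3 is therefore expected to stay close to compound 2, with a step of about no change at the digits printed from compound 2 to compound 3 (within the scatter), that is, nothing beyond the scatter. The estimate for compound 3 in this assay is 0.45 h, with a range from 0.22 h to 0.9 h.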

Compound 3, half-life: 0.7 h
For compound 3 the middle estimate is 1.6-fold (0.19 log units) below the measured one, and the stated range covers the measured number.
By their numbers in this assay, from the lowest: compounds 1, 2 and 3 (each within the scatter of the next).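

In this assay, compound 3 asks what the earlier pair could not: whether the methyl matters at all, rather than where it sits on the ring. Hydrogen in place of methyl on the aromatic carbon gives a 1.6-fold higher number from compound 2 to compound 3 (0.19 log units; within the scatter) and, read from the 2-methylphenyl, gives a 1.6-fold higher number from compound 1 to compound 3 (0.19 log units; within the scatter) as well, so the three compounds stand within the scatter, and neither the presence of the methyl nor its place on the ring separates them here. No measurement at hand offers an explanation for this result.

The compounds shown carry only hydrogen or methyl on this ring, so it remains open whether a different group there, such as methoxy, chlorine, trifluoromethyl or a carboxylic acid, would move the half-life beyond the scatter. Also open, from the compounds shown here alone, is whether the read-out answers to any other part of the molecule, for instance a longer chain in place of the single saturated chain carbon or a change to the shared core, since all three compounds keep these parts unchanged.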